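Ester for acid on a bile acid receptor agonist core

This account rests on a few compounds, and the source may have more. Where it says the series, first, only, none or still open, it means among the compounds named here.

Measured so far:
Compound 1, `Cc1ccccc1-n1nc(C)c2c1NC(=O)[C@H](C)S[C@@H]2c1ccc(Oc2cccc(C(=O)O)c2)cc1`: "not active" (no number reported)
Compound 2, `COc1cccc(Oc2ccc([C@H]3S[C@@H](C)C(=O)Nc4c3c(C)nn4-c3ccccc3C)cc2)c1`: 1700 nM
Compound 3, `Cc1ccccc1-n1nc(C)c2c1NC(=O)[C@H](C)S[C@@H]2c1ccc(Oc2ccccc2C(=O)O)cc1`: "not active" (no number reported)

In an assay on isolated protein for agonist activity at Bile acid receptor (Homo sapiens), read by AlphaScreen, with a stated time of 30 min (on this read-out lower numbers stand for an effect already at smaller amounts and higher numbers for an effect only at larger amounts of compound), compound 2 gives 1700 nM. Compound 3 gives no number in this assay; it is reported as "not active" (no number reported), as is compound 1. Compound 3 therefore stands without a single value among the three measured compounds.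

Compound 4, `COC(=O)c1ccc(-c2ccc([C@H]3S[C@@H](C)C(=O)Nc4c3c(C)nn4-c3ccccc3C)cc2)cc1`, has not been measured yet. It differs from compound 3 in one place: 4-(methoxycarbonyl)phenyl in place of 2-carboxyphenoxy on an aromatic carbon. Going by the values given here, no step between measured compounds exists for this change, so the size of the step is open. Among the compounds with values here, since compound 2, the one measured compound without a carboxylic acid, gives 1700 nM, compound 4 is expected to land near it, at an estimated 2000 nM, within 500 nM to 8000 nM.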

Compound 4, half-maximal effective concentration: "not active" (no number reported)
The entry for compound 4 holds no number; no gap can be computed for the estimate.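

Compound 3 and compound 4 are both reported as "not active" with no number, so no step can be read between them. No measured property accounts for this result. As far as these compounds go, how far 2-carboxyphenoxy and 4-(methoxycarbonyl)phenyl differ in effect remains open.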